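The compounds below may be only part of what the source reports. "The series", "measured", "known", "first", "only" and "open" are said of these compounds alone.

Compound 2 `COc1cccc(NC(=O)Oc2cc(=O)n(CCCO)c3c2CC(CC=C(C)C)C(C)(C)C3)c1` stands lowest of the two numbers in a functional assay on PANC-1 cells (Homo sapiens) for inhibition, read by MTT assay, with a stated time of 24 h, tested at 10 uM (on this read-out higher numbers stand for more inhibition at the one concentration tested (going by the name of the read-out) and lower numbers for less inhibition), where compound 2 gives 16.2%. Compound 1 `CC(C)=CCC1Cc2c(OCCCOc3ccc(Cl)cc3)cc(=O)n(CCCO)c2CC1(C)C` gives 22.7% in this assay, and the two values lie within the scatter of each other. Compound 3 `CC(C)=CCC1Cc2c(OC(=O)Nc3ccc(F)cc3)cc(=O)n(CCCO)c2CC1(C)C` differs from compound 2 by 4-fluorophenyl in place of 3-methoxyphenyl on an amide-type nitrogen. Among the compounds with values here, the only measured step, a number 6.5 percentage points lower from compound 1 to compound 2 (within the scatter), changed the group on an oxygen on an aromatic ring rather than the group on the amide-type nitrogen, so it bears only loosely on this change, and it was small. Compound 3 is therefore expected to show a step of a number 1.8 percentage points higher from compound 2 to compound 3 (within the scatter), nothing beyond the scatter. Compound 3 is estimated at 18%, with a range from 7% to 30%.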

Compound 3, a percentage reported as inhibition, at one concentration (the size of the read-out at that concentration, not a potency): 71.2%
Beside the measured number, compound 3's estimate is 53.2 percentage points below it; measured number outside the range, above it.
By their numbers in this assay, from the lowest: compounds 2 and 1 (each within the scatter of the next); then compound 3.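

In this assay, the group on the amide-type nitrogen turns out to matter strongly: 4-fluorophenyl in place of 3-methoxyphenyl gives a number 55 percentage points higher from compound 2 to compound 3 (beyond the scatter). With a number 48.5 percentage points higher from compound 1 to compound 3 (beyond the scatter), the carbamoyl type of group on the oxygen does not by itself hold the number low, as the 3-methoxyphenyl version had suggested. Nothing available explains this jump. Whether it comes from the fluorine, its place on the ring or the loss of the methoxy group stays open: phenyl, 3-fluorophenyl and 4-methoxyphenyl are not among the compounds shown. As far as these compounds go, how 4-chlorophenyl or cyclohexyl on that nitrogen would read also stays open.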